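A triazole aryl swap on a chalcone scaffold

A few compounds are considered here, and "the series" means these few. Any claim that something is new, unique, unknown or untested is made for them only; others in the source may bear on it.

In a functional assay on RAW264.7 cells (Mus musculus) for inhibition, with a stated time of 4 days (on this read-out lower numbers stand for stronger inhibition and higher numbers for weaker inhibition), three compounds have been measured. Compound 1 `COc1cc(/C=C/C(=O)c2cccc(-n3cc(-c4ccccc4C(F)(F)F)nn3)c2)ccc1O` gives 5070 nM. Compound 2 `COc1ccc(/C=C/C(=O)c2cccc(-n3cc(C(C)(C)O)nn3)c2)cc1O` gives 17100 nM. Compound 3 `COc1ccc(/C=C/C(=O)c2cccc(-n3cc(-c4ccc(C)cc4)nn3)c2)cc1O` gives 1700 nM, the lowest of the three numbers; compound 1 is its nearest neighbour and compound 2 its furthest. Within the data shown here, the one single-point step available, a 10-fold lower number from compound 2 to compound 3 (1.00 log units; beyond the scatter), shows that the group on the triazole carbon moves the read-out strongly.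

Compound 4 `COc1ccc(/C=C/C(=O)c2cccc(-n3cc(-c4ccccc4C(F)(F)F)nn3)c2)cc1O` differs from compound 3 in that place: 2-(trifluoromethyl)phenyl in place of 4-methylphenyl on an aromatic carbon. Among the measured compounds shown here, no measured step compares these two aryl groups directly. Compound 1 carries the same 2-(trifluoromethyl)phenyl on a core whose hydroxy and methoxy groups are arranged differently, and its value of 5070 nM sits well above that of compound 3. The expectation is therefore a moderate step upward, a 2.1-fold higher number from compound 3 to compound 4 (0.31 log units; beyond the scatter), with compound 4 estimated at 3500 nM in this assay, in a range from 1200 nM to 10000 nM.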

Compound 4, half-maximal inhibitory concentration: 9120 nM
Estimate against measurement, compound 4: 2.6-fold (0.42 log units) below; the measured number falls inside the stated range.
By their numbers in this assay, from the lowest: compound 3; then compounds 1, 4 and 2 (each within the scatter of the next, the first and the last beyond it).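

In this assay the change to 2-(trifluoromethyl)phenyl gives a 5.4-fold higher number from compound 3 to compound 4 (0.73 log units; beyond the scatter) and so shows that an aryl group on this aromatic carbon does not by itself carry the low number of compound 3. Set against the 1-hydroxy-1-methylethyl group, the same aryl group gives a 1.9-fold lower number from compound 2 to compound 4 (0.27 log units; within the scatter) and so is not told apart from it, unlike 4-methylphenyl. Exchanging 4-hydroxy-3-methoxyphenyl for 3-hydroxy-4-methoxyphenyl gives a 1.8-fold higher number from compound 1 to compound 4 (0.25 log units; within the scatter) and so does not separate the two arrangements when 2-(trifluoromethyl)phenyl is present, and no measurement here explains any of these steps.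

The compounds shown leave open whether the step to compound 4 follows the trifluoromethyl group or the change from a 4-substituted to a 2-substituted phenyl, which a 4-(trifluoromethyl)phenyl or 2-methylphenyl group could separate. On these data alone, how a phenyl group bearing an amine or a carboxylic acid would read at this position also remains open.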